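Swapping Allyl for Cyclohexyl: Expected Effect on Paw Edema

The source may report more compounds than this note shows. Statements on the series, on what has been measured and on what is new or still open speak of the compounds shown alone.

The measured compounds and their values:
Compound 1, `C=CCNc1nnc(-c2cc(-c3ccc(F)cc3F)ccc2O)o1`: 36.6%
Compound 2, `C=CCNc1nnc(-c2cc(-c3ccc(F)cc3F)ccc2O)s1`: 57.2%
Compound 3, `Oc1ccc(-c2ccc(F)cc2F)cc1-c1nnc(NC2CCCCC2)s1`: 41.4%

All three were tested in a functional assay on the whole organism (strain BALB/c) for inhibition, with Mus musculus as the target, read by paw edema, with a stated time of 4 h, at a dose of 50 mg/kg by the oral route; a higher number here means more inhibition at the dose given (going by the name of the read-out), a lower number less inhibition. Compound 2 and compound 3 share one core, and the change between them, (cyclohexyl in place of allyl on a nitrogen on an aromatic ring), gave a number 15.8 percentage points lower from compound 2 to compound 3 (beyond the scatter). Compound 1 and compound 2 carry different cores; the difference between the two cores is not broken down here, and their values show compound 1 with the lower number in this assay. Compound 1 and compound 3 lie within the scatter of each other, so nothing is said of their order.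

Compound 4, `Oc1ccc(-c2ccc(F)cc2F)cc1-c1nnc(NC2CCCCC2)o1`, is not yet measured. It differs from compound 1 by cyclohexyl in place of allyl on a nitrogen on an aromatic ring, the same change that turns compound 2 into compound 3, at a place described in identical words. Because the earlier step was a number 15.8 percentage points lower from compound 2 to compound 3 (beyond the scatter), a downward step of similar size is expected from compound 1 to compound 4 in this assay, namely a number 14.6 percentage points lower from compound 1 to compound 4 (beyond the scatter), though compound 1 starts lower and this rests on a single pair. Compound 4 is therefore estimated at 22%, between 8% and 38%.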

Compound 4, a percentage reported as inhibition, in the whole organism at one dose (the size of the read-out at that dose, not a potency): 23.8%
The estimate for compound 4 lay 1.8 percentage points below the measured number; the measured number falls inside the stated range.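

In this assay, changing allylamino to cyclohexylamino gave a number 12.8 percentage points lower from compound 1 to compound 4 (beyond the scatter), and this step can be set beside the same change on the other core: the same change on two cores in this assay, a number 15.8 percentage points lower (beyond the scatter) from compound 2 to compound 3 and a number 12.8 percentage points lower (beyond the scatter) from compound 1 to compound 4, 3 percentage points apart, within the scatter of two such steps. On these two cores, then, the drop in inhibition carried over at a similar size, although the starting values differ, with compound 1 at 36.6% and compound 2 at 57.2%. Within the data shown here, the finding rests on only two pairs, at one dose and one time, so it does not show that the change would behave the same way on any further core, and it gives no reason why cyclohexyl gives less inhibition than allyl in either pair.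

The compounds shown leave open how other groups on that nitrogen would fare, such as a longer chain, a benzyl group or a free amine. They also leave open whether the order of allyl and cyclohexyl would hold at other doses or at other times.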